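The source may report more compounds than this note shows. Statements on the series, on what has been measured and on what is new or still open speak of the compounds shown alone.

Measured in a functional assay on HeLa cells (Homo sapiens) for cytotoxicity, read by resazurin assay, with a stated time of 72 h; on this read-out lower numbers stand for stronger inhibition and higher numbers for weaker inhibition:
Compound 1 `CCSC(=S)SCC(=O)c1ccc(OC)cc1`: 1960 nM
Compound 2 `CCNC(=S)SCC(=O)c1ccc(OC)cc1`: 7800 nM

Of these two numbers, compound 1 holds the lower, at 1960 nM. Compound 3 `COc1ccc(C(=O)CSC(=S)SCCOc2ccccc2)cc1` keeps the core of compound 1 and differs from it as follows: phenoxy in place of hydrogen on a saturated chain carbon, two bonds along the chain from a sulfur. Going by the values given here, no measured compound carries phenoxy, so the data do not test this change directly. Among the compounds with values here, the only guide is a 4.0-fold higher number from compound 1 to compound 2 (0.60 log units; beyond the scatter), a modest step that exchanges ethylsulfanyl for ethylamino on a thiocarbonyl carbon. Going by these compounds, compound 3 retains the sulfur that this step removed, so the loss seen there is not expected to recur, and the effect of the added phenoxy remains unknown. In this assay, the expected outcome is therefore no change beyond the scatter, although a modest move in either direction is possible. The estimated step is a 1.0-fold higher number from compound 1 to compound 3 (0.01 log units; within the scatter). For compound 3 the estimate is 2000 nM. The expected range runs from 600 nM to 7000 nM.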

Compound 3, half-maximal inhibitory concentration: 5460 nM
Estimate against measurement, compound 3: 2.7-fold (0.44 log units) below, within the range that was stated.
By their numbers in this assay, from the lowest: compound 1; then compounds 3 and 2 (each within the scatter of the next).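

In this assay, phenoxy in place of hydrogen on a saturated chain carbon, two bonds along the chain from a sulfur, brings a 2.8-fold higher number from compound 1 to compound 3 (0.44 log units; beyond the scatter) as a modest step beyond the scatter. Going by these compounds alone, this gives the first reading at this position, which compound 1 and compound 2 share unchanged: the added phenoxy, with its six-membered aromatic ring, does not give a lower number than hydrogen, and compound 1 remains the lowest of the three. No measured property of these compounds bears on this rise.

Going by these compounds, whether the step belongs to the ring or to the oxygen stays open, as a plain phenyl at the same carbon would be needed to separate them. Also open, on these data alone, is how a carboxylic acid or an amine would read at this position.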